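The source may report more compounds than this note shows. Statements on the series, on what has been measured and on what is new or still open speak of the compounds shown alone.

Among the measured compounds shown here, compound 2, with the structure `COc1ccc(-n2nc(C)c3c(-c4ccc(F)cc4)c(/C=C/[C@@H](O)C[C@@H](O)CC(=O)O)c(C(C)C)nc32)cc1`, gives 48.7% in an in vivo functional assay on the whole organism for inhibition of 3-hydroxy-3-methylglutaryl-coenzyme A reductase (Rattus norvegicus), at a dose of 2 mg/kg by the oral route (a lower number here means a weaker effect, a higher number a stronger effect of the compound at the dose given), the higher of the two numbers so far, though compound 1, with the structure `Cc1nn(Cc2ccccc2)c2nc(C(C)C)c(/C=C/[C@@H](O)C[C@@H](O)CC(=O)O)c(-c3ccc(F)cc3)c12`, gives 45.1%, and the step of a number 3.6 percentage points higher from compound 1 to compound 2 (within the scatter) lies within the scatter. Compound 3, with the structure `Cc1nn(C)c2nc(C(C)C)c(/C=C/[C@@H](O)C[C@@H](O)CC(=O)O)c(-c3ccc(F)cc3)c12`, carries a change of methyl in place of 4-methoxyphenyl on an aromatic nitrogen. For the measured compounds named here, no measured step replaces an aromatic group with a methyl at this nitrogen; the only step known, a number 3.6 percentage points higher from compound 1 to compound 2 (within the scatter), swapped one aromatic group for another and changed little. Compound 3 is therefore expected to give about 40%, between 20% and 60%, an estimated step of a number 8.7 percentage points lower from compound 2 to compound 3 (within the scatter).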

Compound 3, a percentage reported as inhibition, in the whole organism at one dose (the size of the read-out at that dose, not a potency): 48.1%
Compound 3: the middle estimate sits 8.1 percentage points below what was measured; the range from low to high includes it.
By their numbers in this assay, from the lowest: compounds 1, 3 and 2 (each within the scatter of the next).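

At this aromatic nitrogen, the three compounds show that an aromatic ring on the substituent is not needed to keep the effect in this assay: methyl in place of 4-methoxyphenyl gives a number 0.6 percentage points lower from compound 2 to compound 3 (within the scatter), and hydrogen in place of phenyl on the chain carbon gives a number 3 percentage points higher from compound 1 to compound 3 (within the scatter). A single methyl thus serves here as well as the larger benzyl and 4-methoxyphenyl groups. No available measurement speaks to why these compounds read alike. From the compounds shown here alone, whether a longer chain ending in an amine or a carboxylic acid at this nitrogen would shift the read-out remains open. So does whether these compounds would still read alike at other doses.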